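A few compounds are considered here, and "the series" means these few. Any claim that something is new, unique, unknown or untested is made for them only; others in the source may bear on it.

Compound 1, drawn as `CC[C@@H]1C(=O)N(C)c2cnc(-n3ccnc3-c3ccccc3)nc2N1[C@@H]1CCOC1`, gives 21 nM in an assay on isolated protein for inhibition of serine/threonine-protein kinase PLK2 (Homo sapiens), read by TR-FRET, with a stated time of 60 min; on this read-out lower numbers stand for stronger inhibition and higher numbers for weaker inhibition; this is the lowest of the two numbers available, with compound 2, `CC[C@@H]1C(=O)N(C)c2cnc(-n3ccnc3-c3ccc(F)cc3)nc2N1[C@H]1CCOC1`, at 33 nM, which stays within the scatter of compound 1. Compound 3, `CC[C@@H]1C(=O)N(C)c2cnc(-n3ccnc3-c3ccccc3)nc2N1C1CCCC1`, has not yet been measured; it differs from compound 1 by cyclopentyl in place of oxolan-3-yl on a nitrogen on an aromatic ring in a ring. Among the compounds with values here, no measured pair shows the effect of such a change, so only a small step is expected in this assay, in either direction or none beyond the scatter. For compound 3 the expected value is 30 nM, within 10 nM to 90 nM. The estimate amounts to a step of a 1.4-fold higher number from compound 1 to compound 3 (0.15 log units; within the scatter).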

Compound 3, half-maximal inhibitory concentration: 5 nM
Compound 3: the middle estimate sits 6.0-fold (0.78 log units) above what was measured; the whole stated range lies above it.
By their numbers in this assay, from the lowest: compound 3; then compounds 1 and 2 (each within the scatter of the next).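

In this assay, placing cyclopentyl instead of oxolan-3-yl on this nitrogen gives a 4.2-fold lower number from compound 1 to compound 3 (0.62 log units; beyond the scatter) and this step lies beyond the scatter. Both groups are five-membered rings with 5 heavy atoms, so this position responds to a change that removes the ring oxygen, with its hydrogen-bond acceptor, and the defined stereocentre, while leaving ring size unchanged.

The compounds shown leave open whether cyclohexyl, an isopropyl chain or a ring carrying an amine would lower the number further at this position. Nothing available explains the step.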